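A Methylbenzyl Amide After Three Close Values

A few compounds are considered here, and "the series" means these few. Any claim that something is new, unique, unknown or untested is made for them only; others in the source may bear on it.

In a functional assay on A549 cells (Homo sapiens) for inhibition, read by MTT assay, with a stated time of 48 h (on this read-out higher numbers stand for weaker inhibition and lower numbers for stronger inhibition), compound 1 (`COc1ccc2c(=O)c(/C=C/C(=O)NCc3ccccc3)coc2c1`) gives 11800 nM and compound 2 (`COc1ccc2c(=O)c(/C=C/C(=O)Nc3cc(C)ccc3C)coc2c1`) gives 15500 nM while compound 3 (`COc1ccc(NC(=O)/C=C/c2coc3cc(OC)ccc3c2=O)cc1`) gives 23000 nM on the same read-out. Compound 3 therefore stands level with the other two. The steps of a 1.9-fold higher number from compound 1 to compound 3 (0.29 log units; within the scatter) and a 1.5-fold higher number from compound 2 to compound 3 (0.17 log units; within the scatter) both stay within the scatter, as does a 1.3-fold higher number from compound 1 to compound 2 (0.12 log units; within the scatter) too. Compound 4 (`COc1ccc2c(=O)c(/C=C/C(=O)NCc3ccc(C)cc3)coc2c1`) carries 4-methylbenzyl in place of 4-methoxyphenyl on an amide-type nitrogen. Among the measured compounds shown here, compound 1 alone has benzyl on that nitrogen (11800 nM), and no measured step tests 4-methylbenzyl itself. No change beyond the scatter is therefore expected in this assay. The expected step is small (a 1.6-fold lower number from compound 3 to compound 4 (0.22 log units; within the scatter)). Compound 4 is estimated at 14000 nM (expected range 7000 nM to 28000 nM).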

Compound 4, half-maximal inhibitory concentration: > 100000 nM
Compound 4 ended at the assay's limit; the forecaster's own chance of this, stated with the estimate: 3%; middle value at least 7.1-fold (0.85 log units) away from the limit.
By their numbers in this assay, from the lowest: compounds 1, 2 and 3 (each within the scatter of the next). At a limit, above all of these: compound 4.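

Compound 4 reads as a limit and not as a number: the limit of > 100000 nM in this assay, at which 1 of the 4 values shown sits. On the amide-type nitrogen, where the three earlier groups stayed within the scatter of one another, this change gives steps beyond it (an at least 4.3-fold higher number from compound 3 to compound 4 (0.63 log units; beyond the scatter)) and (an at least 6.4-fold higher number from compound 2 to compound 4 (0.80 log units; beyond the scatter)). The closest comparison shows that a single methyl in place of hydrogen on an aromatic carbon of the benzyl group is enough to move the read-out beyond the scatter (an at least 8.4-fold higher number from compound 1 to compound 4 (0.92 log units; beyond the scatter)).

The compounds shown leave open whether a chlorine or an amine on that aromatic carbon would act as the methyl does.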